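Fluoro-to-hydrogen swap on two linker lengths in a triazole series

The compounds below may be only part of what the source reports. "The series", "measured", "known", "first", "only" and "open" are said of these compounds alone.

Of the compounds shown here, three have been measured in an assay on cells (strain Sprague-Dawley) for inhibition of Polyunsaturated fatty acid 5-lipoxygenase (Rattus norvegicus), with a stated time of 30 min; on this read-out lower numbers stand for stronger inhibition and higher numbers for weaker inhibition. Compound 1 `CC(=O)Oc1ccc(/C=C/C(=O)OCCSc2nc(-c3ccc(S(N)(=O)=O)cc3)n(-c3ccc(F)cc3)n2)cc1OC(C)=O` gives 1060 nM. Compound 2 `CC(=O)Oc1ccc(/C=C/C(=O)OCCSc2nc(-c3ccc(S(N)(=O)=O)cc3)n(-c3ccccc3)n2)cc1OC(C)=O` gives 1110 nM; the change from compound 1 to compound 2 is hydrogen in place of fluoro on an aromatic carbon, and the step is a 1.0-fold higher number from compound 1 to compound 2 (0.02 log units; within the scatter). Compound 3 `CC(=O)Oc1ccc(/C=C/C(=O)OCCCSc2nc(-c3ccc(S(N)(=O)=O)cc3)n(-c3ccc(F)cc3)n2)cc1OC(C)=O` gives 1030 nM. Compound 3 and compound 1 share most of their structure, but the difference between the two cores is not broken down here; their two values lie within the scatter of each other, as do those of compound 3 and compound 2.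

Compound 4 `CC(=O)Oc1ccc(/C=C/C(=O)OCCCSc2nc(-c3ccc(S(N)(=O)=O)cc3)n(-c3ccccc3)n2)cc1OC(C)=O` has not yet been measured. It differs from compound 3 by hydrogen in place of fluoro on an aromatic carbon, the same change as from compound 1 to compound 2, made at the same place. In the measured pair the change left the read-out within the scatter, and nothing in the three values suggests that the core of compound 3 would respond differently. The step from compound 3 to compound 4 in this assay is therefore expected to be a 1.0-fold higher number from compound 3 to compound 4 (0.01 log units; within the scatter), because of the step of a 1.0-fold higher number from compound 1 to compound 2 (0.02 log units; within the scatter) seen in the measured pair. Compound 4 is estimated at 1050 nM, with a range from 600 nM to 1850 nM.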

Compound 4, half-maximal inhibitory concentration: 1070 nM
Beside the measured number, compound 4's estimate is 1.0-fold (0.01 log units) below it; the measured number falls inside the stated range.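

The change from 4-fluorophenyl to phenyl can now be read on two cores in this assay, and the new step is a 1.0-fold higher number from compound 3 to compound 4 (0.02 log units; within the scatter). Set beside the earlier step, it gives the same picture: the same change on two cores in this assay, a 1.0-fold higher number (0.02 log units; within the scatter) from compound 1 to compound 2 and a 1.0-fold higher number (0.02 log units; within the scatter) from compound 3 to compound 4, 1.0-fold (0.00 log units) apart, within the scatter of two such steps. Within these four compounds, the change therefore carries from the core of compound 1 to the core of compound 3 with no readable difference, but both steps lie within the scatter, so the agreement shows only that the swap leaves the read-out unmoved on these two cores and says nothing about how it would behave on any other core or in a case where the change has a readable effect.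

The compounds shown leave open whether any other group on that aromatic carbon, such as chloro, methoxy or trifluoromethyl, would shift the read-out, as only fluoro and hydrogen appear there. Also open, from the compounds shown here alone, is whether the swap would stay equally silent with a longer chain between the sulfur and the ester, or with free hydroxyl groups in place of the acetate esters.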